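A few compounds are considered here, and "the series" means these few. Any claim that something is new, unique, unknown or untested is made for them only; others in the source may bear on it.

Compound 2 `O=C1N/C(=N/c2csc(-c3ccc(Cl)cc3)c2)S/C1=C\c1ccccn1` and compound 1 `CCCCCC/C=C1\S/C(=N\c2csc(-c3ccc(Cl)cc3)c2)NC1=O` share one core and differ only in the group attached to a double-bonded chain carbon bound to a double-bonded ring carbon. Among the measured compounds shown here, in a functional assay on MCF7 cells (Homo sapiens) for cytotoxicity, read by MTT assay, with a stated time of 72 h (a higher number here means a weaker inhibitor, a lower number a stronger inhibitor), compound 2 gives 30200 nM, the single measured number in this set. For compound 1 the result is a limit of the assay, > 50000 nM, shown by the limit of > 50000 nM in this assay, at which 1 of the 2 values shown sits. The step of an at least 1.6-fold lower number from compound 1 to compound 2 (0.21 log units; that floor lies within the scatter) therefore sits at a floor that lies within the scatter. Compound 3 `O=C1N/C(=N/c2csc(-c3ccc(Cl)cc3)c2)S/C1=C\c1ccc(F)cc1` follows with 4-fluorophenyl in place of pyridin-2-yl on a double-bonded chain carbon bound to a double-bonded ring carbon. For the measured compounds named here, the one measured step concerns the same position but a different exchange, and it gives no clear direction, so a second aromatic ring in the same place is expected to leave the number near where compound 2 sits. The step of a 1.0-fold lower number from compound 2 to compound 3 (0.00 log units; within the scatter) is expected to stay within the scatter. Compound 3 is estimated at 30000 nM, within 10000 nM to 90000 nM.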

Compound 3, half-maximal inhibitory concentration: > 50000 nM
Compound 3: only a limit was reported; the forecaster's own chance of this, stated with the estimate: 30%; middle value at least 1.6-fold (0.22 log units) from the limit.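

Exchanging pyridin-2-yl for 4-fluorophenyl on a double-bonded chain carbon bound to a double-bonded ring carbon gives an at least 1.6-fold higher number from compound 2 to compound 3 (0.21 log units; that floor lies within the scatter), so neither a real loss nor a gain can be claimed. What is new is that an aromatic ring at this place does not by itself yield a measured number in this assay, since the carbon-only ring of compound 3 does not. Compound 1 and compound 3 both end at a limit of the assay rather than a number, and the step between them cannot be read: the limit of > 50000 nM in this assay, at which 2 of the 3 values shown sit.

Going by these compounds, how far compound 3 really lies from compound 2 stays open. So does whether an amine, a carboxylic acid or a shorter chain than hexyl at this place would bring a clearly lower number.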